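Acetophenone to chalcone: expected shift for compound 4

This account rests on a few compounds, and the source may have more. Where it says the series, first, only, none or still open, it means among the compounds named here.

Measured in a functional assay on HeLa cells (Homo sapiens) for cytotoxicity, read by resazurin assay, with a stated time of 72 h; a lower number here means a stronger inhibitor, a higher number a weaker inhibitor:
- compound 1 `COc1cc(OC)c(C(=O)/C=C/c2ccccc2)c(OC)c1`: 5200 nM
- compound 2 `C=CCOc1ccccc1Cc1c(OC)cc(OC)c(C(=O)/C=C/c2ccccc2)c1OC`: 5800 nM
- compound 3 `COCOc1cc(OC)cc(OC)c1C(C)=O`: 14000 nM

Compound 3 has the highest of the three numbers at 14000 nM. Compound 1 gives 5200 nM and compound 2 gives 5800 nM. The gap from compound 3 to each of these two lies beyond the scatter.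

The next structure, compound 4 `COCOc1cc(OC)cc(OC)c1C(=O)/C=C/c1ccccc1`, has 2-phenylethenyl in place of methyl on a carbonyl carbon. Going by the values given here, no measured step covers this exchange directly. Among the compounds with values here, the only measured step is a 1.1-fold higher number from compound 1 to compound 2 (0.05 log units; within the scatter), which lies within the scatter, so a large substituent on an aromatic carbon left the number unmoved in that pair. Compound 1 and compound 2 both carry 2-phenylethenyl on the carbonyl carbon, and both have lower numbers than compound 3, though three compounds make a thin basis for a pattern.

A drop beyond the scatter is therefore expected in this assay, towards the level of compound 1 at 5200 nM. The expected step is a 2.8-fold lower number from compound 3 to compound 4 (0.45 log units; beyond the scatter). For compound 4 the estimated value is 5000 nM, with an expected range of 2200 nM to 11000 nM.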

Compound 4, half-maximal inhibitory concentration: 4800 nM
Compound 4: the middle estimate sits 1.0-fold (0.02 log units) above what was measured, within the range that was stated.
By their numbers in this assay, from the lowest: compounds 4, 1 and 2 (each within the scatter of the next); then compound 3.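

In this assay, going by these compounds alone, the exchange of methyl for 2-phenylethenyl on the carbonyl carbon now has a direct reading, a 2.9-fold lower number from compound 3 to compound 4 (0.46 log units; beyond the scatter), and this is the first single change at this position that lies beyond the scatter. Until now, the link between 2-phenylethenyl and the lower numbers rested only on a comparison of compounds differing in more than one place. The second new step, a 1.1-fold lower number from compound 1 to compound 4 (0.03 log units; within the scatter), lies within the scatter, so methoxy in place of hydrogen on a saturated chain carbon bound to an oxygen on an aromatic ring leaves compound 4 level with compound 1, and the number is tied to the group on the carbonyl carbon rather than to this change; no available finding explains the step at the carbonyl carbon.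

From the compounds shown here alone, the reading at this position rests on one matched pair, so it remains open whether the double bond or the aromatic ring of 2-phenylethenyl accounts for the step. A saturated 2-phenylethyl group on the carbonyl carbon, or an amine or carboxylic acid on the ring of 2-phenylethenyl, would bear on this and on how far the step extends.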